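Amide versus urea linkers in the SNB-75 cytotoxicity series

A few compounds are considered here, and "the series" means these few. Any claim that something is new, unique, unknown or untested is made for them only; others in the source may bear on it.

Measured so far:
compound 1, `COc1cc(-c2nn(-c3cccc(NC(=O)c4cccc(C(F)(F)F)c4)c3)cc2-c2ccncc2)ccc1Cl`: > 50000 nM
compound 2, `COc1cc(-c2nn(-c3cccc(NC(=O)Nc4cccc(C(F)(F)F)c4)c3)cc2-c2ccncc2)ccc1Cl`: 50000 nM

Compound 1 carries the 3-(trifluoromethyl)phenyl group directly on the carbonyl carbon; in a functional assay on SNB-75 cells (Homo sapiens) for inhibition, read by sulforhodamine B assay, with a stated time of 48 h (a lower number here means that less compound is tolerated, a higher number that more compound is tolerated), compound 1 gives > 50000 nM, which is a limit of the assay and not a number. Compound 2 carries (3-(trifluoromethyl)phenyl)amino on that carbonyl carbon instead, and in this assay compound 2 gives 50000 nM. Compound 2 therefore stands as the only number shown; the further value shown is a limit. On these data alone, the measured step of a number no higher from compound 1 to compound 2 (the limit leaves the size open) is bounded only by the limit of > 50000 nM in this assay, at which 1 of the 2 values shown sits, so its size stays open.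

Compound 3, `COc1cc(-c2nn(-c3cccc(NC(=O)c4ccc(Cl)c(C(F)(F)F)c4)c3)cc2-c2ccncc2)ccc1Cl`, has not been measured. The change from compound 2 is 4-chloro-3-(trifluoromethyl)phenyl in place of (3-(trifluoromethyl)phenyl)amino on a carbonyl carbon. Among the measured compounds shown here, this undoes the urea-to-amide difference of the measured step and adds a chlorine on the aryl ring, so the only step bearing on it is the one from compound 1 to compound 2, whose size is not readable. A step back toward the limit, or none beyond the scatter, is expected: no change at the digits printed from compound 2 to compound 3 (within the scatter). Compound 3 is accordingly expected to give 50000 nM, within 20000 nM to 100000 nM, with a substantial chance that only a limit is reported.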

Compound 3, concentration lethal to 50% of the cells: > 32500 nM
Compound 3 gave a limit, no number (the forecaster's own chance of this, stated with the estimate: 55%); the middle value is on the limit's open side.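

In this assay compound 3 gives > 32500 nM, a limit of the assay and not a number. No step can be read from it, either between compound 2 and compound 3 or between compound 1 and compound 3. On these data alone, whether chloro in place of hydrogen on an aromatic carbon shifts the value, and how far the amides compound 1 and compound 3 lie from the urea compound 2, stays open.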